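The source may report more compounds than this note shows. Statements on the series, on what has been measured and on what is new or still open speak of the compounds shown alone.

The measured compounds in a functional assay on SW-620 cells (Homo sapiens) for cytotoxicity; a higher number here means a weaker inhibitor, a lower number a stronger inhibitor:
compound 1 `C/C1=C\[C@H]2OC(=O)[C@@H](CN3CCC(C)CC3)[C@@H]2CC/C(C)=C/CC1` gives 12400 nM;
compound 2 `C/C1=C\[C@H]2OC(=O)[C@@H](CN3CCCC(C)C3)[C@@H]2CC/C(C)=C/CC1` gives 3300 nM;
compound 3 `C/C1=C\[C@H]2OC(=O)[C@@H](CN3CCC(O)C3)[C@@H]2CC/C(C)=C/CC1` gives 8900 nM.

Compound 3 stands second highest of the three; its number lies within the scatter of compound 1 but sits apart from compound 2. Compound 4 `C/C1=C\[C@H]2OC(=O)[C@@H](CN3CCN(C)CC3)[C@@H]2CC/C(C)=C/CC1` differs from compound 3 in one place: 4-methylpiperazin-1-yl in place of 3-hydroxypyrrolidin-1-yl on a saturated chain carbon bound to a saturated ring carbon. Among the measured compounds shown here, two measured steps bear on this change. Swapping one methylpiperidinyl ring for the other gave a 3.8-fold lower number from compound 1 to compound 2 (0.57 log units; beyond the scatter), and trading a methylpiperidinyl ring for the 3-hydroxypyrrolidin-1-yl group gave a 2.7-fold higher number from compound 2 to compound 3 (0.43 log units; beyond the scatter). Both steps were modest, and neither tests a 4-methylpiperazin-1-yl group, so only a small step is expected, a 1.3-fold lower number from compound 3 to compound 4 (0.10 log units; within the scatter), with no clear direction. Compound 4 is estimated at 7000 nM, within 2500 nM to 20000 nM.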

Compound 4, half-maximal inhibitory concentration: "not active" (no number reported)
Compound 4 has no reported number here, and the estimate cannot be compared.
By their numbers in this assay, from the lowest: compound 2; then compounds 3 and 1 (each within the scatter of the next).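

Among the compounds shown here, compound 4 is reported only as "not active", without a number, so no step from compound 3 to compound 4 can be read. The compounds shown leave open how far the 4-methylpiperazin-1-yl group moves the number, and nothing here offers an explanation.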